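This account rests on a few compounds, and the source may have more. Where it says the series, first, only, none or still open, it means among the compounds named here.

Measured so far in a functional assay on A549 cells (Homo sapiens) for antiproliferative activity, read by MTT assay, with a stated time of 72 h; a lower number here means a stronger inhibitor, a higher number a weaker inhibitor:

- compound 1 `COc1cc2ncnc(Nc3ccc(Br)cc3F)c2cc1OCCCN1CCNCCNCCNCC1`: 15200 nM
- compound 2 `COc1cc2ncnc(Nc3ccc(F)c(Br)c3)c2cc1OCCCN1CCNCCNCCNCC1`: 11800 nM
- compound 3 `COc1cc2ncnc(Nc3ccc(OCc4cccc(F)c4)c(Cl)c3)c2cc1OCCCN1CCNCCNCCNCC1`: 3400 nM

Compound 2 stands second highest of the three numbers. Its nearest neighbour is compound 1: the step of a 1.3-fold lower number from compound 1 to compound 2 (0.11 log units; within the scatter) is within the scatter, so the two read as equal. Among the compounds with values here, compound 3 sits furthest away with a lower number, and that gap lies beyond the scatter; no single-point step links compound 2 and compound 3, so only the two values themselves can be compared.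

The next compound is compound 4 `COc1cc2ncnc(Nc3cccc(I)c3)c2cc1OCCCN1CCNCCNCCNCC1`. Relative to compound 2 the change is 3-iodophenyl in place of 3-bromo-4-fluorophenyl on a nitrogen on an aromatic ring. Within the data shown here, the only measured step that bears on this change is the one between compound 1 and compound 2, which also altered the halogen pattern on the ring attached to the nitrogen and gave a 1.3-fold lower number from compound 1 to compound 2 (0.11 log units; within the scatter), within the scatter. Nothing measured here tests an iodine on that ring, nor the loss of the fluorine. On that basis a small step is expected in this assay, most likely not beyond the scatter, with a slight lean toward a lower number.

Compound 4 is therefore estimated at 8000 nM, with a range from 3500 nM to 18000 nM. The expected step is a 1.5-fold lower number from compound 2 to compound 4 (0.17 log units; within the scatter).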

Compound 4, half-maximal inhibitory concentration: 14500 nM
Compound 4: the middle estimate sits 1.8-fold (0.26 log units) below what was measured, and the stated range covers the measured number.
By their numbers in this assay, from the lowest: compound 3; then compounds 2, 4 and 1 (each within the scatter of the next).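

In this assay, 3-iodophenyl in place of 3-bromo-4-fluorophenyl on a nitrogen on an aromatic ring gives a 1.2-fold higher number from compound 2 to compound 4 (0.09 log units; within the scatter), and 3-iodophenyl in place of 4-bromo-2-fluorophenyl at the same place gives a 1.0-fold lower number from compound 1 to compound 4 (0.02 log units; within the scatter). The earlier compounds shown here showed only a rearrangement of bromine and fluorine on this ring; the new result adds that replacing bromine with iodine while also losing fluorine leaves the number within the scatter, so all three halogen-bearing rings read as equal in this assay. No evidence at hand explains this flat reading.

From the compounds shown here alone, a plain phenyl, or a phenyl carrying an amine or a carboxylic acid, on the same nitrogen remains open, so it cannot yet be said whether a halogen on this ring matters at all. Within the data shown here, whether the value of compound 3, 3400 nM, comes from the group on its nitrogen also cannot be read, since no single-place step links compound 3 to the other compounds.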